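The compounds below may be only part of what the source reports. "The series", "measured", "known", "first", "only" and "open" are said of these compounds alone.

Measured compounds in a functional assay on the whole organism (strain Wistar) for inhibition, with Rattus norvegicus as the target, read by paw edema, with stated times of 60 min and 1 h, at a dose of 100 mg/kg by the oral route; on this read-out higher numbers stand for more inhibition at the one dose given (going by the name of the read-out) and lower numbers for less inhibition:
compound 1 `COc1cc2c(cc1OC)C(CC(N)=O)CC2` gives 18.8%
compound 2 `COc1cc2c(cc1OC)C(CC(=O)N(C)C)CC2` gives 25%
compound 3 `CCNC(=O)CC1CCc2cc(OC)c(OC)cc21` gives 15.6%

Compound 2 gives the highest of these three numbers, yet it stands apart from neither neighbour: the step of a number 6.2 percentage points higher from compound 1 to compound 2 (within the scatter) and the step of a number 9.4 percentage points lower from compound 2 to compound 3 (within the scatter) are both within the scatter, so the number of compound 2 cannot be set apart from those of the other two. The step of a number 3.2 percentage points lower from compound 1 to compound 3 (within the scatter) is within the scatter as well.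

The unmeasured compound 4 `CCCNC(=O)CC1CCc2cc(OC)c(OC)cc21` differs from compound 2 in one place: propylamino in place of dimethylamino on a carbonyl carbon. Within the data shown here, the step that bears most directly on it is the one from compound 2 to compound 3, where ethylamino replaced dimethylamino on the same carbonyl carbon and the number moved only within the scatter. The steps from compound 1 to compound 2 and from compound 1 to compound 3 also stayed within the scatter. Compound 4 is therefore expected to show no step beyond the scatter in this assay, the expected step being a number 7 percentage points lower from compound 2 to compound 4 (within the scatter). For compound 4 the estimate is 18%, with a range from 5% to 32%.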

Compound 4, a percentage reported as inhibition, in the whole organism at one dose (the size of the read-out at that dose, not a potency): 18.8%
Beside the measured number, compound 4's estimate is 0.8 percentage points below it; the range from low to high includes it.
By their numbers in this assay, from the lowest: compounds 3, 1, 4 and 2 (each within the scatter of the next).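

In this assay, propylamino on the carbonyl carbon gives a number 6.2 percentage points lower from compound 2 to compound 4 (within the scatter), so this exchange, which adds one hydrogen-bond donor, cannot be told apart from dimethylamino at this position. Extending the ethyl chain by one carbon gives a number 3.2 percentage points higher from compound 3 to compound 4 (within the scatter), and propyl in place of hydrogen on the amide-type nitrogen gives no change at the digits printed from compound 1 to compound 4 (within the scatter), so all four groups on the carbonyl carbon now fall within the scatter of one another, with no compound going against this. Nothing available here offers an explanation for these numbers.

As far as these compounds go, it remains open whether any group at this position can give a step beyond the scatter, for example a longer chain such as hexylamino, a piperidine ring or a carboxylic acid. From the compounds shown here alone, because each compound has a number at only one dose, their potencies also remain open.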